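Amino in place of hydroxy in a benzophenone series

A few compounds are considered here, and "the series" means these few. Any claim that something is new, unique, unknown or untested is made for them only; others in the source may bear on it.

Compound 1 `COc1ccc(C(=O)c2ccc(OC)c(O)c2OC)cc1`: "not determined" (no result reported)
Compound 2 `COc1ccc(C(=O)c2cc(OC)c(OC)c(OC)c2)c(OC)c1O`: 23.5 nM

The study reports cytotoxicity in a functional assay on HL-60 cells (Homo sapiens) for cytotoxicity, read by sulforhodamine B assay, with a stated time of 48 h; on this read-out higher numbers stand for weaker inhibition of growth and lower numbers for stronger inhibition of growth. Compound 1 `COc1ccc(C(=O)c2ccc(OC)c(O)c2OC)cc1` carries no result in this assay, the entry reading "not determined" (no result reported). Within the data shown here, compound 2 `COc1ccc(C(=O)c2cc(OC)c(OC)c(OC)c2)c(OC)c1O` is therefore the only compound with a number: in this assay compound 2 gives 23.5 nM, and it stands alone, with nothing to compare against.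

Compound 3 `COc1ccc(C(=O)c2cc(OC)c(OC)c(OC)c2)c(OC)c1N` has not been measured. It differs from compound 2 by amino in place of hydroxy on an aromatic carbon. Among the measured compounds shown here, with no step between measured compounds reported, the size of the expected change rests on the change itself: amino in place of hydroxy, one heavy atom for one, the same count of hydrogen-bond donors and acceptors, no net charge. A modest weakening is expected, around the scatter or a little beyond it, so the estimated step from compound 2 to compound 3 is a 1.9-fold higher number from compound 2 to compound 3 (0.28 log units; within the scatter).

In this assay compound 3 is expected to give about 45 nM, within a range from 10 nM to 220 nM.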

Compound 3, concentration for 50% growth inhibition: 33.1 nM
Compound 3: middle estimate off by 1.4-fold (0.13 log units), on the high side; the measured number falls inside the stated range.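

In this assay, amino in place of hydroxy on this aromatic carbon, ortho to two methoxy groups, gives a 1.4-fold higher number from compound 2 to compound 3 (0.15 log units; within the scatter), so the two compounds cannot be told apart. Among these compounds, this is the first comparison at this position, and it shows that hydroxy is not needed there to keep growth inhibition in this cell assay, at least when amino takes its place. Nothing measured here bears on why the two groups behave alike.

From the compounds shown here alone, what stays open is whether a group that differs more from hydroxy, such as a methoxy, an acetamide or a carboxylic acid, would leave the read-out as little changed on this carbon. Whether amino can stand in for hydroxy on a different core is also left open, and compound 1, with no number, offers no help.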